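A few compounds are considered here, and "the series" means these few. Any claim that something is new, unique, unknown or untested is made for them only; others in the source may bear on it.

Measured in an ADME assay on L1210/0 cells (Mus musculus) for cytotoxicity, with a stated time of 48 h; a lower number here means a stronger inhibitor, a higher number a weaker inhibitor:
- compound 1 `O=c1[nH]c(=O)n([C@H]2C[C@H](O)[C@@H](CO)O2)cc1C#CCO`: > 200000 nM, a limit
- compound 2 `O=c1[nH]c(=O)n([C@H]2C[C@H](O)[C@@H](CO)O2)cc1C#CCCO`: > 200000 nM, a limit
- compound 3 `CC#Cc1cn([C@H]2C[C@H](O)[C@@H](CO)O2)c(=O)[nH]c1=O`: > 200000 nM, a limit

Compound 3 has no number of its own in this assay, only a limit, and the other two compounds share its position: the limit of > 200000 nM in this assay, at which 3 of the 3 values shown sit.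

The next compound is compound 4 `O=c1[nH]c(=O)n([C@H]2C[C@H](O)[C@@H](CO)O2)cc1C1SCCS1`. Going there from compound 3, the prop-1-yn-1-yl group leaves an aromatic carbon and a five-membered non-aromatic ring with 2 hetero atoms takes its place: a group of 5 heavy atoms (3 carbon, 2 sulfur; one five-membered non-aromatic ring with 2 hetero atoms) in place of a group of 3 heavy atoms (3 carbon; no ring), on an aromatic carbon.

Three measured steps alter the chain at this same place: a step that the two limits leave unreadable from compound 1 to compound 2, a step that the two limits leave unreadable from compound 1 to compound 3 and a step that the two limits leave unreadable from compound 2 to compound 3. None of them has a readable size, and all three keep the triple bond that compound 4 loses. They offer no size to carry over, so no step beyond the usual scatter is expected, in either direction.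

The expected change is a number no higher from compound 3 to compound 4 (the limit leaves the size open). For compound 4 the estimate is 200000 nM, with an expected range from 80000 nM to 400000 nM.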

Compound 4, half-maximal inhibitory concentration: > 200000 nM
Compound 4 was reported as a limit; the forecaster's own chance of this, stated with the estimate: 75%; the middle value sits exactly at the limit.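

Compound 4, like compound 1, compound 2 and compound 3, is reported only as a limit, so no step among these four compounds has a readable size: the limit of > 200000 nM in this assay, at which 4 of the 4 values shown sit. The compounds shown leave open how large any difference between them in this assay might be.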